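The compounds below may be only part of what the source reports. "The series", "measured", "known", "first", "only" and "open" are said of these compounds alone.

Working notes on the series. In an assay on isolated protein for inhibition of protoporphyrinogen oxidase (Homo sapiens), read by capillary electrophoresis (a lower number here means a stronger inhibitor, a higher number a weaker inhibitor), compound 1 `CCOC(=O)C(C)(C)Sc1nc2cc(-n3nc(C(C)(C)C)sc3=O)c(Cl)cc2s1` gives 34400 nM and compound 2 `CCOC(=O)CSc1nc2cc(-n3nc(C(C)(C)C)sc3=O)c(Br)cc2s1` gives 15600 nM; compound 2 holds the lowest of the two numbers, and compound 1 sits a step above it that lies beyond the scatter. Compound 3 `CCOC(=O)C(C)(C)Sc1nc2cc(-n3nc(C(C)(C)C)sc3=O)c(Br)cc2s1` differs from compound 2 by 1-(ethoxycarbonyl)-1-methylethyl in place of (ethoxycarbonyl)methyl on a sulfur, with the bromine kept. Within the data shown here, no pair of measured compounds differs in one place only, so the effect of this change is untested here. The expected step from compound 2 to compound 3 in this assay is a 1.9-fold higher number from compound 2 to compound 3 (0.28 log units; within the scatter), a rise in the number. For compound 3 the estimate is 30000 nM, within 12000 nM to 75000 nM.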

Compound 3, inhibition constant: 43500 nM
For compound 3 the middle estimate is 1.5-fold (0.16 log units) below the measured one, and the stated range covers the measured number.
By their numbers in this assay, from the lowest: compound 2; then compounds 1 and 3 (each within the scatter of the next).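

Among these compounds, with the bromine kept, 1-(ethoxycarbonyl)-1-methylethyl in place of (ethoxycarbonyl)methyl on a sulfur gives a 2.8-fold higher number from compound 2 to compound 3 (0.45 log units; beyond the scatter) in this assay and is the first direct reading of this change. With 1-(ethoxycarbonyl)-1-methylethyl kept, bromo in place of chloro on an aromatic carbon gives a 1.3-fold higher number from compound 1 to compound 3 (0.10 log units; within the scatter) and leaves no separable halogen effect in this pair. Nothing measured on the series bears on the origin of either step.

On these data alone, whether the sulfur change gives a similar step with chloro in place of bromo stays open. So does the outcome of a carboxylic acid in place of the ethyl ester, or of a longer chain on the sulfur.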